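This account rests on a few compounds, and the source may have more. Where it says the series, first, only, none or still open, it means among the compounds named here.

Compound 1 `CC(C)(C)c1ccc(NC(=O)N2CCC3(CC2)C(=O)N(c2ccccc2)[C@H]3c2ccccc2)cc1` carries a phenyl group on the saturated ring carbon of its core, and in a functional assay on HEK293 cells for antagonist activity at transient receptor potential cation channel subfamily V member 1 (Homo sapiens), read by FLIPR (on this read-out lower numbers stand for stronger inhibition and higher numbers for weaker inhibition), compound 1 gives 12 nM. Compound 2 `CC(C)(C)c1ccc(NC(=O)N2CCC3(CC2)C(=O)N(c2ccccc2)[C@@H]3c2ccccc2)cc1` is its mirror image: the fact that compounds 1 and 2 differ only in the configuration as drawn. For compound 2 the result in this assay is "not determined" (no result reported), so no number is available and compound 2 cannot be placed against compound 1 at all. Compound 3 `CC(C)(C)c1ccc(NC(=O)N2CCC3(CC2)CN(c2ccccc2)C3=O)cc1` follows from compound 2 by hydrogen in place of phenyl on a saturated ring carbon; the stereocentre disappears with that group. Going by the values given here, no measured pair shows what removing this phenyl does. Since compound 1 gives 12 nM while keeping the phenyl, the change is expected to weaken inhibition, giving a higher number in this assay, probably beyond the usual scatter. Compound 3 is therefore expected to give about 120 nM, within a range from 20 nM to 1000 nM.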

Compound 3, half-maximal inhibitory concentration: 59 nM
For compound 3 the middle estimate is 2.0-fold (0.31 log units) above the measured one; low and high end bracket the measured number.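

Putting hydrogen in place of phenyl on this saturated ring carbon gives a 4.9-fold higher number from compound 1 to compound 3 (0.69 log units; beyond the scatter), the first measured sign that the phenyl adds to inhibition at this position. The loss is only modest: in this assay compound 3 still gives 59 nM, so in this pair inhibition does not depend on the phenyl. The step from compound 2 cannot be read, so this comparison rests on compound 1 alone, and it holds for one configuration only, because the two phenyl compounds are mirror images: the fact that compounds 1 and 2 differ only in the configuration as drawn.

On these data alone, what the other configuration contributes remains open. So does whether a methyl group, a hydroxyl group or an amine on this carbon would keep the gain seen with phenyl.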